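Methylamino in place of methylsulfanyl on compound 1

This account rests on a few compounds, and the source may have more. Where it says the series, first, only, none or still open, it means among the compounds named here.

Measured in a functional assay on K562 cells (Homo sapiens), read by MTT assay, with a stated time of 72 h; a lower number here means a stronger inhibitor, a higher number a weaker inhibitor:
- compound 1 `CSc1ncnc2c1c(-c1ccoc1)cn2[C@@H]1O[C@H](CO)[C@@H](O)[C@H]1O`: 3250 nM
- compound 2 `CSc1ncnc2c1c(-c1ccsc1)cn2[C@@H]1O[C@H](CO)[C@@H](O)[C@H]1O`: > 20000 nM (a limit, not a number)
- compound 3 `CSc1ncnc2c1c(-c1ccccc1)cn2[C@@H]1O[C@H](CO)[C@@H](O)[C@H]1O`: > 20000 nM (a limit, not a number)

Within the data shown here, compound 1 is the strongest of these three and the only one with an actual number. The other two are described by the limit of > 20000 nM in this assay, at which 2 of the 3 values shown sit. Replacing its furan-3-yl group with thiophen-3-yl gave an at least 6.1-fold higher number from compound 1 to compound 2 (0.78 log units; beyond the scatter). Replacing the same group with phenyl gave an at least 6.1-fold higher number from compound 1 to compound 3 (0.78 log units; beyond the scatter). Between the other two compounds, the limits leave nothing to compare.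

Compound 4 `CNc1ncnc2c1c(-c1ccoc1)cn2[C@@H]1O[C@H](CO)[C@@H](O)[C@H]1O` keeps the furan-3-yl group of compound 1 and changes a different place: methylamino in place of methylsulfanyl on an aromatic carbon. In words, this is methylamino in place of methylsulfanyl on an aromatic carbon.

Neither measured step touches that place, so they give no size or direction for this swap. Among the measured compounds shown here, they show only that a change elsewhere on the shared core can move the value beyond the scatter. The expectation in this assay is therefore no step beyond the scatter, held with wide uncertainty. The expected change is a 1.1-fold lower number from compound 1 to compound 4 (0.03 log units; within the scatter). For compound 4 the estimated value is 3000 nM, expected to lie between 400 nM and 20000 nM.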

Compound 4, half-maximal inhibitory concentration: > 20000 nM
Compound 4: only a limit was reported; the forecaster's own chance of this, stated with the estimate: 25%; at least 6.6-fold (0.82 log units) between middle value and limit.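

Until now only the furan-3-yl group had been changed, and this result shows that the methylsulfanyl place on the shared core also matters in this assay: methylamino in place of methylsulfanyl gave an at least 6.1-fold higher number from compound 1 to compound 4 (0.78 log units; beyond the scatter), although the swap keeps the same number of heavy atoms and only exchanges sulfur for nitrogen and adds a hydrogen-bond donor. Compound 4 gives > 20000 nM, which is a limit and not a number. Both places on compound 1 have now been changed, and each change tested left a compound without a number, so compound 1 is the only one of the four with a measured value: the limit of > 20000 nM in this assay, at which 3 of the 4 values shown sit.

As far as these compounds go, how far compound 4 lies past the limit remains unknown, so the step has a lower bound but no actual size. Also open, from the compounds shown here alone, is whether a plain amine, a methoxy group or a longer chain such as ethylsulfanyl at this place would give a value close to that of compound 1, and whether methylamino would act the same way alongside thiophen-3-yl or phenyl.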